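The compounds below may be only part of what the source reports. "The series", "measured", "known", "first", "only" and "open" are said of these compounds alone.

In a functional assay on SK-MEL-147 cells (Homo sapiens) for cytotoxicity, read by MTT assay, with a stated time of 24 h (on this read-out lower numbers stand for an effect already at smaller amounts and higher numbers for an effect only at larger amounts of compound), three compounds built on a shared core have been measured. Compound 1 `CCOC(=O)c1cc([Se]Cc2ccccc2)c2cc(OC)ccc2n1` carries benzyl on a selenium and gives 40700 nM there. Compound 2 `CCCCC#Cc1cc(C(=O)OCC)nc2ccc(OC)cc12` has no selenium and gives 7200 nM there. On these data alone, for compound 3 `CCOC(=O)c1cc([Se]c2ccc(OC)cc2)c2cc(OC)ccc2n1` the read-out is >= 54300 nM as a limit of the assay and not a number, so its true place on the scale stays unknown.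

Compound 4 `CCOC(=O)c1cc([Se]c2ccccc2C)c2cc(OC)ccc2n1` departs from compound 3 at one point, with 2-methylphenyl in place of 4-methoxyphenyl on a selenium is the counted difference. The nearest measured change is the exchange of groups on selenium, an at least 1.3-fold higher number from compound 1 to compound 3 (0.12 log units; that floor lies within the scatter) and a floor that lies within the scatter. The other step, a 5.7-fold lower number from compound 1 to compound 2 (0.75 log units; beyond the scatter) and beyond the scatter, bears less directly, as it removes the selenium group that compound 4 keeps. A swap on selenium is therefore expected to bring no change beyond the scatter in this assay and perhaps a slightly lower number. The expected change is an at least 1.3-fold lower number from compound 3 to compound 4 (0.13 log units; that floor lies within the scatter) and no more than that. For compound 4 the estimate is 40000 nM with an expected range from 15000 nM to 70000 nM in this read-out.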

Compound 4, half-maximal effective concentration: 38900 nM
Estimate against measurement, compound 4: 1.0-fold (0.01 log units) above; the range from low to high includes it.
By their numbers in this assay, from the lowest: compound 2; then compounds 4 and 1 (each within the scatter of the next). At a limit, above all of these: compound 3.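

In this assay, compound 4 gives a number, not a limit, for a methyl-bearing phenyl group on a selenium whose other neighbour is aromatic carbon. With 2-methylphenyl in place of benzyl on a selenium, the step is a 1.0-fold lower number from compound 1 to compound 4 (0.02 log units; within the scatter), so this read-out does not separate these two groups at this place. The gap to the selenium-free compound 2 also holds with this new group on selenium, as seen in a 5.4-fold higher number from compound 2 to compound 4 (0.73 log units; beyond the scatter), which lies beyond the scatter and matches in direction the step already seen from compound 1 to compound 2. Compound 3 has only a limit and not a number: the limit of >= 54300 nM in this assay, at which 1 of the 4 values shown sits. With 2-methylphenyl in place of 4-methoxyphenyl on a selenium, the step is an at least 1.3-fold lower number from compound 3 to compound 4 (0.14 log units; that floor lies within the scatter), which gives a floor and not a size.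

Open is whether the higher numbers belong to the selenium itself or to the group it carries, as the steps shown replace the two together. Also open, on these data alone, is whether an amine or a carboxylic acid on the phenyl ring, or a longer chain on the selenium, would move the number in this assay beyond the scatter.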